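The source may hold more compounds than are shown below. What is called first, only, known or untested is meant among the compounds shown, and "the series" means these compounds.

In a functional assay on MDA-MB-231 cells (Homo sapiens) for antiproliferative activity, read by MTT assay, with a stated time of 24 h (a higher number here means a weaker inhibitor, a lower number a stronger inhibitor), compound 1 `COC(=O)c1scc(-c2ccc(NC(=O)c3ccccn3)cc2)c1OC` gives 8250 nM and compound 2 `COC(=O)c1scc(-c2ccc(NC(=O)c3cc(I)ccc3F)cc2)c1OC` gives 16500 nM, so these two values lie within the usual scatter of each other. Compound 3 `COC(=O)c1scc(-c2ccc(NC(=O)c3ccc(C#N)nc3)cc2)c1OC` carries 6-cyanopyridin-3-yl in place of 2-fluoro-5-iodophenyl on a carbonyl carbon. For the measured compounds named here, the only measured step, a 2.0-fold higher number from compound 1 to compound 2 (0.30 log units; within the scatter), also exchanged the ring group at this place and stayed within the scatter. This single step is thin evidence, but it gives no reason to expect a real shift in this assay. The expected change is a 1.4-fold lower number from compound 2 to compound 3 (0.14 log units; within the scatter), which is within the scatter. The estimate for compound 3 is 12000 nM, with an expected range of 4000 nM to 33000 nM.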

Compound 3, half-maximal inhibitory concentration: 28500 nM
Beside the measured number, compound 3's estimate is 2.4-fold (0.38 log units) below it; low and high end bracket the measured number.
By their numbers in this assay, from the lowest: compounds 1, 2 and 3 (each within the scatter of the next, the first and the last beyond it).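

In this assay the ring on the carbonyl carbon now shows a change beyond the scatter: 6-cyanopyridin-3-yl in place of pyridin-2-yl gives a 3.5-fold higher number from compound 1 to compound 3 (0.54 log units; beyond the scatter), a modest step. In place of 2-fluoro-5-iodophenyl, the same group gives a 1.7-fold higher number from compound 2 to compound 3 (0.24 log units; within the scatter), so these two groups cannot be ranked. Nothing measured here explains the larger step. Going by these compounds, whether it comes from the nitrile or from the change to a pyridin-3-yl group stays open, as does the outcome with a plain pyridin-3-yl group or a phenyl ring carrying a carboxylic acid or an amine.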